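Chloro for fluoro on the aryl ring of compound 2

The source may hold more compounds than are shown below. What is called first, only, known or untested is meant among the compounds shown, and "the series" means these compounds.

Going by the values given here, in a functional assay on HT-29 cells (Homo sapiens) for cytotoxicity, read by MTT assay, with a stated time of 72 h (a higher number here means a weaker inhibitor, a lower number a stronger inhibitor), compound 2 (`O=C(Nc1ccc(Oc2ccnc3[nH]ccc23)c(F)c1)c1nnn(-c2ccc(F)c(F)c2)c1C(F)(F)F`) gives 320 nM, the lowest of the two numbers so far. Among the compounds with values here, the other measured member, compound 1 (`Cc1c(C(=O)Nc2ccc(Oc3ccnc4[nH]ccc34)c(F)c2)nnn1-c1ccc(F)c(Cl)c1`), gives 1060 nM in this assay, a higher number beyond the scatter; the two differ in more than one place, so no single step is drawn between them. Compound 3 (`O=C(Nc1ccc(Oc2ccnc3[nH]ccc23)c(F)c1)c1nnn(-c2ccc(F)c(Cl)c2)c1C(F)(F)F`) is not yet measured. It differs from compound 2 by chloro in place of fluoro on an aromatic carbon, the change sitting on an aromatic carbon of a six-membered aromatic ring of carbon only. Within the data shown here, with no measured pair isolating this exchange, the expectation is a step in this assay of a 1.1-fold higher number from compound 2 to compound 3 (0.04 log units; within the scatter), not beyond the scatter in either direction. Compound 3 is therefore estimated at 350 nM in this assay, with a range from 150 nM to 850 nM.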

Compound 3, half-maximal inhibitory concentration: 630 nM
Beside the measured number, compound 3's estimate is 1.8-fold (0.26 log units) below it; measured number inside the range.
By their numbers in this assay, from the lowest: compounds 2, 3 and 1 (each within the scatter of the next, the first and the last beyond it).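

In this assay, 3,4-difluorophenyl to 3-chloro-4-fluorophenyl gives a 2.0-fold higher number from compound 2 to compound 3 (0.29 log units; within the scatter) and so, at this position, chloro and fluoro cannot be told apart in this series. Going by these compounds alone, the first single-place reading at the other site, trifluoromethyl in place of methyl on an aromatic carbon, gives a 1.7-fold lower number from compound 1 to compound 3 (0.23 log units; within the scatter) and is likewise not separable from the scatter. The gap between compound 1 and compound 2, which lies beyond the scatter, thus divides into two steps that each stay within it, and nothing available bears on the reason for either step.

Open, as far as these compounds go, is whether an amine or a methoxy group at this aryl position would give a step beyond the scatter. Also open, from the compounds shown here alone, is whether a nitrile in place of trifluoromethyl would do so.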